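This account rests on a few compounds, and the source may have more. Where it says the series, first, only, none or still open, it means among the compounds named here.

Compound 1, `CN(C(=O)N1CC[C@H](n2cnc3cc(-c4ccc(Cl)cc4)sc3c2=O)C1)[C@H]1CCN(C2CCC2)C1`, gives 1 nM in an assay on isolated protein for binding affinity to melanin-concentrating hormone receptor 1 (Homo sapiens); a higher number here means a weaker inhibitor, a lower number a stronger inhibitor. Compound 2, `CN(C(=O)N1CC[C@H](n2cnc3cc(-c4ccc(Cl)cc4)sc3c2=O)C1)[C@H]1CCN(C2CCC(C)(C)CC2)C1`, gives 2 nM in this assay. Compound 3, `CN(C(=O)N1CC[C@H](n2cnc3cc(-c4ccc(Cl)cc4)sc3c2=O)C1)[C@H]1CCN(CC2CCCCC2)C1`, gives 50 nM in this assay.

Compound 3 carries the highest number of the three: the steps of a 50-fold higher number from compound 1 to compound 3 (1.70 log units; beyond the scatter) and a 25-fold higher number from compound 2 to compound 3 (1.40 log units; beyond the scatter) are both large, while a 2.0-fold higher number from compound 1 to compound 2 (0.30 log units; within the scatter) stays within the scatter. Compound 4, `CN(C(=O)N1CC[C@H](n2cnc3cc(-c4ccc(Cl)cc4)sc3c2=O)C1)[C@H]1CCN(Cc2ccoc2)C1`, differs from compound 3 by furan-3-yl in place of cyclohexyl on a saturated chain carbon bound to an amine nitrogen in a ring. Among the measured compounds shown here, no measured step changes the ring on a saturated chain carbon bound to the amine nitrogen while keeping that carbon; the large steps to compound 3 concern the chain itself, which compound 4 retains. Compound 4 is therefore expected to stay near compound 3, with the step estimated as a 1.3-fold lower number from compound 3 to compound 4 (0.10 log units; within the scatter). For compound 4 the estimate in this assay is 40 nM, between 10 nM and 150 nM.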

Compound 4, inhibition constant: 4 nM
The estimate for compound 4 lay 10-fold (1.00 log units) above the measured number; the measured number lies below the stated range.
By their numbers in this assay, from the lowest: compounds 1, 2 and 4 (each within the scatter of the next, the first and the last beyond it); then compound 3.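

In this assay the ring on the saturated chain carbon proves to matter: furan-3-yl in place of cyclohexyl gives a 13-fold lower number from compound 3 to compound 4 (1.10 log units; beyond the scatter) and shows that the chain alone does not bring the high number of compound 3. (Furan-3-yl)methyl gives a 2.0-fold higher number from compound 2 to compound 4 (0.30 log units; within the scatter) against 4,4-dimethylcyclohexyl and a 4.0-fold higher number from compound 1 to compound 4 (0.60 log units; beyond the scatter) against cyclobutyl, so a chain-linked ring can come close to the directly attached rings. No evidence at hand explains the furan-3-yl step. Whether the ring oxygen or the aromatic ring accounts for it stays open, a question that phenyl or tetrahydrofuran-3-yl on the same chain carbon would address.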